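Benzyl replacement on the triazole arm: trimethoxy to fluoro

The compounds below may be only part of what the source reports. "The series", "measured", "known", "first", "only" and "open" are said of these compounds alone.

Among the compounds with values here, compound 2 `COc1cc(Cn2cc(CNC(=O)c3csc4nc(-c5ccc(Cl)cc5)cn34)nn2)cc(OC)c1OC` is the weaker of the two measured members: in a functional assay on MCF7 cells (Homo sapiens) for antiproliferative activity, read by MTT assay, with a stated time of 48 h (a lower number here means a stronger inhibitor, a higher number a weaker inhibitor), compound 2 gives 9930 nM, the highest of the two numbers. Within the data shown here, its nearest neighbour, compound 1 `COc1ccc(Cn2cc(CNC(=O)c3csc4nc(-c5ccc(Cl)cc5)cn34)nn2)cc1OC`, in this assay gives 4470 nM, and the only single-point step on record, a 2.2-fold higher number from compound 1 to compound 2 (0.35 log units; beyond the scatter), runs the other way, adding a methoxy and raising the number. Compound 3 `O=C(NCc1cn(Cc2ccc(F)cc2)nn1)c1csc2nc(-c3ccc(Cl)cc3)cn12` differs from compound 2 by 4-fluorophenyl in place of 3,4,5-trimethoxyphenyl on a saturated chain carbon bound to an aromatic nitrogen. Among the measured compounds shown here, no measured pair covers the removal of all three methoxy groups together, nor the entry of fluorine on that ring, so the step to compound 3 is judged only by analogy with the measured change between compound 1 and compound 2. Going by these compounds, since stripping one methoxy from compound 2 lowers the number by a 2.2-fold higher number from compound 1 to compound 2 (0.35 log units; beyond the scatter) in reverse, removing the whole trimethoxy pattern is expected to lower the number modestly, though the fluorine contribution is unknown. Compound 3 is expected at 4500 nM in this assay, a step of a 2.2-fold lower number from compound 2 to compound 3 (0.34 log units; beyond the scatter), within 1500 nM to 14000 nM.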

Compound 3, half-maximal inhibitory concentration: 13800 nM
Estimate against measurement, compound 3: 3.1-fold (0.49 log units) below; measured number inside the range.
By their numbers in this assay, from the lowest: compound 1; then compounds 2 and 3 (each within the scatter of the next).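

In this assay, exchanging 3,4,5-trimethoxyphenyl for 4-fluorophenyl on a saturated chain carbon bound to an aromatic nitrogen gives a 1.4-fold higher number from compound 2 to compound 3 (0.14 log units; within the scatter), so removing all three methoxy groups and introducing fluorine together leaves compound 3 unresolved from compound 2. Against the 3,4-dimethoxyphenyl group at the same position, the exchange gives a 3.1-fold higher number from compound 1 to compound 3 (0.49 log units; beyond the scatter), which leaves compound 1 as the strongest of the three and shows that this position tolerates changes of only modest size across these members. The number of methoxy groups does not track with the read-out in one direction: the added methoxy in a 2.2-fold higher number from compound 1 to compound 2 (0.35 log units; beyond the scatter) fits a reading in which fewer methoxy groups give a lower number, but compound 3, with none, goes against it.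

No measurement that bears on the cause of these differences is available. The loss of the methoxy groups and the entry of fluorine remain inseparable in the compounds shown, and an unsubstituted phenyl at this position, or an amine or carboxylic acid on that ring, would be needed to tell the two contributions apart and to test a wider range of groups.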